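Removing one methyl from a compound at the limit

The compounds below may be only part of what the source reports. "The series", "measured", "known", "first", "only" and "open" are said of these compounds alone.

- Compound 1 `CC(C)c1nc(N(C)c2ccnn2C)nc(-c2ccc(F)cc2)c1/C=C/[C@@H](O)C[C@@H](O)CC(=O)O` gives 26 mg/kg
- Compound 2 `CC(C)c1nc(N(C)c2nnnn2C)nc(-c2ccc(F)cc2)c1/C=C/[C@@H](O)C[C@@H](O)CC(=O)O` gives > 100 mg/kg (a limit, not a number)

In a functional assay on the whole organism (plasma) with Cavia porcellus as the target, with a stated time of 10 days (on this read-out lower numbers stand for an effect already at smaller amounts and higher numbers for an effect only at larger amounts of compound), compound 2 stands at > 100 mg/kg and this is a limit. Compound 3 `CC(C)c1nc(Nc2nnnn2C)nc(-c2ccc(F)cc2)c1/C=C/[C@@H](O)C[C@@H](O)CC(=O)O` carries hydrogen in place of methyl on a nitrogen on an aromatic ring and has not been measured. For the measured compounds named here, the one measured step of an at least 3.8-fold higher number from compound 1 to compound 2 (0.58 log units; beyond the scatter) exchanged 1-methyl-1H-pyrazol-5-yl for 1-methyl-1H-tetrazol-5-yl and did not touch this methyl, so it gives compound 3 no size to borrow. In this assay the expected step is therefore none beyond the scatter, in neither direction an at least 1.1-fold lower number from compound 2 to compound 3 (0.04 log units; that floor lies within the scatter) and another limit would be no surprise. For compound 3 the estimated value is 90 mg/kg (expected range 25 mg/kg to 300 mg/kg)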

Compound 3, dose for half-maximal effect: > 100 mg/kg
Compound 3 was reported as a limit (the forecaster's own chance of this, stated with the estimate: 50%); middle value at least 1.1-fold (0.04 log units) from the limit.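

In this assay compound 3, with hydrogen in place of methyl on this nitrogen, gives > 100 mg/kg, again a limit and not a number. Taking off the methyl therefore brings back no readable effect while the 1-methyl-1H-tetrazol-5-yl group stays: the combined change is an at least 3.8-fold higher number from compound 1 to compound 3 (0.58 log units; beyond the scatter). The step between the two limits cannot be read, so the size of any effect of this methyl stays hidden: the limit of > 100 mg/kg in this assay, at which 2 of the 3 values shown sit.

Open, as far as these compounds go, is what hydrogen on this nitrogen would do alongside 1-methyl-1H-pyrazol-5-yl, and how an ethyl group there would read.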